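From amino to nitro on the shared core

The source may report more compounds than this note shows. Statements on the series, on what has been measured and on what is new or still open speak of the compounds shown alone.

Measured in a functional assay on HL-60 cells (Homo sapiens) for antiproliferative activity, read by MTT assay, with a stated time of 72 h; a higher number here means a weaker inhibitor, a lower number a stronger inhibitor:
Compound 1 `COc1cc(-c2ncnn2-c2cccc(N)c2)cc(OC)c1OC`: > 10000 nM
Compound 2 `COc1cc(-c2ncnn2-c2ccc(Cl)c(Cl)c2)cc(OC)c1OC`: > 10000 nM

Compound 1 stands only at a limit, > 10000 nM. Compound 2 also stands at a limit, > 10000 nM. The record so far is the limit of > 10000 nM in this assay, at which 2 of the 2 values shown sit. Compound 3 `COc1cc(-c2ncnn2-c2cccc([N+](=O)[O-])c2)cc(OC)c1OC` brings the change (nitro in place of amino on an aromatic carbon), nitro in place of amino on an aromatic carbon. Within the data shown here, the one measured step is a step that the two limits leave unreadable from compound 1 to compound 2, and it has no readable size. No step beyond the scatter, in either direction, is therefore expected in this assay. The expected step is a step that the limit leaves unreadable from compound 1 to compound 3. For compound 3 the estimated value is 15000 nM, with an expected range of 6000 nM to 40000 nM.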

Compound 3, half-maximal inhibitory concentration: > 10000 nM
Compound 3: only a limit was reported (the forecaster's own chance of this, stated with the estimate: 80%); the middle value does not contradict the limit.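

Compound 3 gives only a limit in this assay, > 10000 nM. Like compound 1, it stands at a limit, so no step between compound 1 and compound 3 can be read. The compounds shown leave open how these groups would rank against one another: the limit of > 10000 nM in this assay, at which 3 of the 3 values shown sit.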